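Removal of the aryl substituent from the pyridine core

The compounds below may be only part of what the source reports. "The series", "measured", "known", "first", "only" and "open" are said of these compounds alone.

Measured compounds:
compound 1, `O=C(NO)c1ccc(/C=C/c2ccnc(-c3cc(F)ccc3O)c2)cc1`, 130 nM
compound 2, `O=C(NO)c1ccc(/C=C/c2ccnc(-c3cccc(O)c3)c2)cc1`, 19 nM
compound 3, `O=C(NO)c1ccc(/C=C/c2ccnc(-c3cccnc3)c2)cc1`, 14 nM

All three share a hydroxamic acid and a shared core; they differ only in the aryl group on the pyridine. In an assay on isolated protein for inhibition of protein deacetylase HDAC6 (Homo sapiens), read by fluorescence, with a stated time of 15 min (a higher number here means a weaker inhibitor, a lower number a stronger inhibitor), compound 3 gives the lowest number of the three. One step is a 1.4-fold lower number from compound 2 to compound 3 (0.13 log units; within the scatter), which is within the scatter, so the two cannot be ordered. The other steps are a 9.3-fold lower number from compound 1 to compound 3 (0.97 log units; beyond the scatter) and a 6.8-fold lower number from compound 1 to compound 2 (0.84 log units; beyond the scatter); both of these are beyond the scatter.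

Compound 4, `O=C(NO)c1ccc(/C=C/c2ccncc2)cc1`, is not yet measured. Relative to compound 3 the change is hydrogen in place of pyridin-3-yl on an aromatic carbon; the place is on an aromatic carbon of a six-membered aromatic ring with one nitrogen, next to the ring nitrogen, meta to a large group. No measured step bears directly on this change: every step shown exchanges one aryl group for another, and none removes the group altogether. The steps do show that this position tolerates variation with only modest shifts. Compound 4 is therefore expected to give 40 nM, between 10 nM and 160 nM, an estimated step of a 2.9-fold higher number from compound 3 to compound 4 (0.46 log units; beyond the scatter).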

Compound 4, half-maximal inhibitory concentration: 130 nM
Estimate against measurement, compound 4: 3.3-fold (0.51 log units) below; the range from low to high includes it.
By their numbers in this assay, from the lowest: compounds 3 and 2 (each within the scatter of the next); then compounds 1 and 4 (each within the scatter of the next).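

Hydrogen in place of pyridin-3-yl gives a 9.3-fold higher number from compound 3 to compound 4 (0.97 log units; beyond the scatter) in this assay, and hydrogen in place of 3-hydroxyphenyl gives a 6.8-fold higher number from compound 2 to compound 4 (0.84 log units; beyond the scatter), so the low numbers of these two aryl compounds are lost once the group is taken away from this carbon next to the ring nitrogen. An aryl group here is not enough on its own, however: compound 1 goes against any simple link between its presence and a low number, as hydrogen in place of 5-fluoro-2-hydroxyphenyl gives no change at the digits printed from compound 1 to compound 4 (within the scatter), so the identity of the group matters as well as its presence. No measurement at hand explains why removal has this effect or why compound 1 sits with the unsubstituted compound.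

Going by these compounds, whether a non-aromatic group at this carbon, such as methyl, an amine or morpholine, would restore the lower numbers remains open. Compound 1 and compound 2 differ in both the fluorine and the placing of the hydroxyl group, so the compounds shown do not separate the contribution of each.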